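A few compounds are considered here, and "the series" means these few. Any claim that something is new, unique, unknown or untested is made for them only; others in the source may bear on it.

Working notes on the series. The shared core is that of compound 1, `CCCC(=O)OCSc1ccccc1C(=O)NCC(N)=O`. In an ADME assay on CEM-SS cells (Homo sapiens) for cytotoxicity, read by XTT assay, with a stated time of 6 days (on this read-out higher numbers stand for lower toxicity in this test and lower numbers for higher toxicity in this test), compound 1 gives > 100 uM, which is a limit of the assay and not a number. Compound 2, `CCCC(=O)OCSc1ccccc1C(=O)Nc1ccccc1C(N)=O`, gives in this assay 50.1 uM. Compound 3, `CCCC(=O)OCSc1ccccc1C(=O)Nc1cccc(C(N)=O)c1`, gives in this assay 17.5 uM. Of the three values at hand, one sits at the limit of > 100 uM in this assay, at which 1 of the 3 values shown sits, so where compound 1 stands is known only as that limit, while compound 2 and compound 3 supply the two numbers the set has.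

Compound 4, `CCCC(=O)OCSc1ccccc1C(=O)NCC(=O)NCC(=O)OC`, has not yet been measured in this assay. It differs from compound 1 by (methoxycarbonyl)methyl in place of hydrogen on an amide-type nitrogen. The (methoxycarbonyl)methyl enters on the amide-type nitrogen whose other neighbour is the carbonyl carbon; the remainder of the core is unchanged.

Going by the values given here, no step between measured compounds is available, so the expectation for compound 4 rests on the limit of compound 1 and the size of the change alone. This estimate means a step that the limit leaves unreadable from compound 1 to compound 4, expected to be none beyond the scatter. Compound 4 is therefore expected to give about 120 uM in this assay, within a range from 50 uM to 300 uM, and is more likely than not to be reported again as a limit rather than a number.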

Compound 4, half-maximal toxic concentration: > 100 uM
Compound 4: a limit, no number; the forecaster's own chance of this, stated with the estimate: 65%; the middle value lies beyond the limit too.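

No step from compound 1 to compound 4 can be read in this assay, because each of the two compounds gives a limit of the assay and not a number: the limit of > 100 uM in this assay, at which 2 of the 4 values shown sit.

The compounds shown leave open whether (methoxycarbonyl)methyl in place of hydrogen on the amide-type nitrogen changes the half-maximal toxic concentration in this assay at all.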